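The compounds below may be only part of what the source reports. "The series", "measured", "known", "first", "only" and "open" are said of these compounds alone.

Compound 1 `O=C(NCc1ccc(F)cc1)c1nc(NCCO)c2cccnc2c1O` carries a 2-hydroxyethylamino group and a hydroxyl on its core. In a functional assay on MDA-MB-435 cells (Homo sapiens) for cytotoxicity, read by MTT assay, with a stated time of 72 h (on this read-out higher numbers stand for weaker inhibition and lower numbers for stronger inhibition), compound 1 gives only a limit, > 20000 nM, and no number. Compound 2 `N[C@H]1CC[C@H](Nc2c(C(=O)NCc3ccc(F)cc3)nc(Br)c3cccnc23)CC1` has a different core, with a bromine and a diaminocyclohexyl group; in this assay compound 2 gives 6000 nM. The difference between the two cores of compound 1 and compound 2 is not broken down here. Compound 3 `C[C@H](NC(=O)c1nc(Br)c2cccnc2c1N[C@H]1CC[C@H](N)CC1)c1ccc(F)cc1` differs from compound 2 by methyl in place of hydrogen on a saturated chain carbon bound to an amide-type nitrogen and an aromatic carbon. In this assay compound 3 gives only a limit, > 10000 nM. The step of an at least 1.6-fold higher number from compound 2 to compound 3 (0.22 log units; that floor lies within the scatter) therefore rests on one side on a limit, the one described by the limit of > 10000 nM in this assay, at which 1 of the 3 values shown sits.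

Compound 4 `C[C@@H](CO)Nc1nc(C(=O)NCc2ccc(F)cc2)c(O)c2ncccc12` has not yet been measured. It differs from compound 1 by methyl in place of hydrogen on a saturated chain carbon bound to a nitrogen on an aromatic ring and a saturated chain carbon. This is the same kind of change as that from compound 2 to compound 3, though not the same: there the methyl enters on a saturated chain carbon bound to an amide-type nitrogen and an aromatic carbon, here on a saturated chain carbon bound to a nitrogen on an aromatic ring and a saturated chain carbon. Since compound 1 already sits at the limit described by the limit of > 20000 nM in this assay, at which 1 of the 3 values shown sits, the expected step that the limit leaves unreadable from compound 1 to compound 4 cannot be checked against a number on either side. Compound 4 is therefore expected to give about 40000 nM in this assay, between 15000 nM and 120000 nM, most likely again reported only as a limit.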

Compound 4, half-maximal inhibitory concentration: > 20000 nM
Compound 4: no number, only a limit; the forecaster's own chance of this, stated with the estimate: 85%; the middle value is on the limit's open side.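

In this assay compound 4 gives only a limit, > 20000 nM. Among the compounds shown here, compound 1 also stands at a limit, so no step from compound 1 to compound 4 can be read: the limit of > 20000 nM in this assay, at which 2 of the 4 values shown sit. The compounds shown leave open whether methyl in place of hydrogen on this saturated chain carbon changes the read-out at all, and how far compound 1 and compound 4 lie past their limit.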